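From an ethylphenyl to a naphthyl on a shared core

This account rests on a few compounds, and the source may have more. Where it says the series, first, only, none or still open, it means among the compounds named here.

Compound 2 `CCc1ccc(-c2cn3ccnc3c(-c3ccc4ncn(Cc5ccccc5)c4c3)n2)cc1` stands highest of the two numbers in a functional assay on MCF7 cells (Homo sapiens) for inhibition, read by sulforhodamine B assay, with a stated time of 48 h, tested at 10 uM (a higher number here means more inhibition at the concentration tested (going by the name of the read-out), a lower number less inhibition), where compound 2 gives 58%. Its nearest neighbour, compound 1 `Fc1ccc(-c2cn3ccnc3c(-c3ccc4ncn(C5CCCCC5)c4c3)n2)cc1`, gives 9.17% in this assay, a number lower by more than the usual scatter; the two differ in more than one place, so only their two values speak. Compound 3 `c1ccc(Cn2cnc3ccc(-c4nc(-c5cccc6ccccc56)cn5ccnc45)cc32)cc1` is built from compound 2 by one change: naphthalen-1-yl in place of 4-ethylphenyl on an aromatic carbon. Going by the values given here, no measured pair isolates such a change. Compound 3 is expected to show a step of a number 8 percentage points lower from compound 2 to compound 3 (within the scatter) that is small or within the scatter. For compound 3 the estimated inhibition is 50%, with a range from 20% to 75%.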

Compound 3, a percentage reported as inhibition, at one concentration (the size of the read-out at that concentration, not a potency): 29.2%
For compound 3 the middle estimate is 20.8 percentage points above the measured one; measured number inside the range.
By their numbers in this assay, from the lowest: compound 1; then compound 3; then compound 2.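

In this assay, going by these compounds alone, the change from 4-ethylphenyl to naphthalen-1-yl gives a number 28.8 percentage points lower from compound 2 to compound 3 (beyond the scatter) and is the first single-place comparison at this aromatic carbon of the shared core. It shows that inhibition depends on which carbon-only aromatic group sits here, although neither group counts any hydrogen-bond donors or acceptors. Nothing at hand explains the step. From the compounds shown here alone, how an amine or a carboxylic acid on the phenyl ring would fare at this place remains open. Going by these compounds, the separate contributions of the two differences between compound 1 and compound 2 also remain open.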